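This account rests on a few compounds, and the source may have more. Where it says the series, first, only, none or still open, it means among the compounds named here.

Working notes on the series in a functional assay on DU-145 cells (Homo sapiens) for inhibition; on this read-out lower numbers stand for stronger inhibition and higher numbers for weaker inhibition. Compound 1 `Oc1cccc(-c2cc(-c3ccc(F)cc3)cc(-c3ccccc3O)n2)c1` gives > 50000 nM, which is a limit of the assay and not a number (the limit of > 50000 nM in this assay, at which 1 of the 3 values shown sits). Compound 2 `Oc1cccc(-c2cc(-c3ccc(F)cc3)cc(-c3cccc(O)c3)n2)c1` gives 7120 nM. Among the compounds with values here, the only single-point step measured so far, an at least 7.0-fold lower number from compound 1 to compound 2 (0.84 log units; beyond the scatter), moves a hydroxyl group and nothing else. Compound 3 `Oc1ccc(-c2cc(-c3ccccc3F)cc(-c3cccc(O)c3)n2)cc1` gives 3160 nM, the lowest of the two numbers recorded, and its value lies under that of compound 2 by more than the scatter; compounds 2 and 3 differ in two places at once, so their values do not tell the two changes apart. Compound 4 `Oc1ccc(-c2cc(-c3ccc(F)cc3)cc(-c3cccc(O)c3)n2)cc1` is the next member; it differs from compound 3 by 4-fluorophenyl in place of 2-fluorophenyl on an aromatic carbon. Within the data shown here, no measured step relocates a fluorine on its ring, and the one step on record concerns a hydroxyl group, so there is no precedent of the same kind to draw on. In this assay the expected step of a 1.1-fold higher number from compound 3 to compound 4 (0.04 log units; within the scatter) is therefore set at none beyond the scatter, with the numbers of compound 3 as the anchor. Compound 4 is estimated at 3500 nM, with a range from 1200 nM to 10000 nM.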

Compound 4, half-maximal inhibitory concentration: 15200 nM
The estimate for compound 4 lay 4.3-fold (0.64 log units) below the measured number, outside the stated range (above it).
By their numbers in this assay, from the lowest: compound 3; then compound 2; then compound 4. At a limit, above all of these: compound 1.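

Moving the fluorine is not neutral in this assay: with both hydroxyphenyl groups held fixed, the change at this carbon opposite the ring nitrogen gives a 4.8-fold higher number from compound 3 to compound 4 (0.68 log units; beyond the scatter), so 2-fluorophenyl is favoured over 4-fluorophenyl in this pair. With 4-fluorophenyl and one 3-hydroxyphenyl group held fixed, the other hydroxyphenyl group now has three measured forms, and the new steps are a 2.1-fold higher number from compound 2 to compound 4 (0.33 log units; beyond the scatter) and an at least 3.2-fold lower number from compound 1 to compound 4 (0.51 log units; beyond the scatter), which give the order 3-hydroxyphenyl, then 4-hydroxyphenyl, then 2-hydroxyphenyl from the lowest number upward. The value of compound 1 is a limit and not a number, so its step gives a bound and no exact size: the limit of > 50000 nM in this assay, at which 1 of the 4 values shown sits.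

The compounds shown leave open whether the gap between 2-fluorophenyl and 4-fluorophenyl carries over to other arrangements of the hydroxyl groups, since only one matched fluorine pair is available. Going by these compounds, it is also open how the series would respond to an amine or a carboxylic acid in place of a hydroxyl group on these rings.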